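Replacing Hydroxy with Isopropyl on the Chain of Compound 1

This account rests on a few compounds, and the source may have more. Where it says the series, first, only, none or still open, it means among the compounds named here.

Compound 1 `O=C(CN(c1ncnc2c1ncn2C1CCCCO1)C1CC1)N[C@@H](CO)C(=O)OCc1ccccc1` holds the highest of the three numbers recorded in a functional assay on the whole organism (Tail, strain ICR) with Mus musculus as the target, in the tail flick test, with a stated time of 60 min, at a dose of 25 umol/kg by the oral route (on this read-out higher numbers stand for a stronger effect at the one dose given and lower numbers for a weaker effect), where compound 1 gives 46.7%; compound 3 `O=C(CN(c1nc(Cl)nc2[nH]cnc12)C1CC1)NCC(=O)OCc1ccccc1` gives 41.9% and compound 2 `CC[C@H](C)[C@H](NC(=O)CN(c1nc(Cl)nc2[nH]cnc12)C1CC1)C(=O)OCc1ccccc1` gives 40.6%, and both lie within the scatter of compound 1. Compound 4 `CC(C)C[C@H](NC(=O)CN(c1ncnc2c1ncn2C1CCCCO1)C1CC1)C(=O)OCc1ccccc1` differs from compound 1 by isopropyl in place of hydroxy on a saturated chain carbon, two bonds along the chain from an amide-type nitrogen and a carbonyl carbon. For the measured compounds named here, one measured step bears on this change, a side-chain exchange on a saturated chain carbon bound to an amide-type nitrogen and a carbonyl carbon in two compounds sharing another core: a number 1.3 percentage points higher from compound 2 to compound 3 (within the scatter). On that basis no shift beyond the scatter is expected for compound 4, and the expected step of a number 1.7 percentage points lower from compound 1 to compound 4 (within the scatter) is small. Compound 4 is therefore estimated at 45%, with a range from 30% to 60%.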

Compound 4, a percentage reported as activity, at one dose (the size of the read-out at that dose, not a potency): 34.2%
The estimate for compound 4 lay 10.8 percentage points above the measured number; low and high end bracket the measured number.
By their numbers in this assay, from the lowest: compounds 4, 2, 3 and 1 (each within the scatter of the next, the first and the last beyond it).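

In this assay, isopropyl in place of hydroxy on this chain carbon gives a number 12.5 percentage points lower from compound 1 to compound 4 (beyond the scatter) on the core of compound 1. The earlier side-chain exchange on another core, a number 1.3 percentage points higher from compound 2 to compound 3 (within the scatter), had shown no such shift, so this result is the first to show a change at this position moving the read-out beyond the scatter. Nothing available explains the step.

Going by these compounds, it remains open whether an amine or a carboxylic acid on this chain carbon would read nearer compound 1 or compound 4. On these data alone, whether the same exchange would give a similar step on the core of compound 2 also remains open.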